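This account rests on a few compounds, and the source may have more. Where it says the series, first, only, none or still open, it means among the compounds named here.

Measured in a functional assay on B16-F10 cells (Mus musculus) for antiproliferative activity, read by MTT assay, with a stated time of 48 h; on this read-out lower numbers stand for stronger inhibition and higher numbers for weaker inhibition:
compound 1 `COc1ccc(/C=C/c2cc(OC)cc(OC)c2/C=C/C(=O)c2ccccc2)cc1` gives 3.7 ug/mL
compound 2 `CCCCCCOc1ccc(C(=O)/C=C/c2c(/C=C/c3ccc(OC)cc3)cc(OC)cc2OC)cc1` gives 10.4 ug/mL
compound 3 `COc1ccc(/C=C/c2cc(OC)cc(OC)c2/C=C/C(=O)c2ccc(C(F)(F)F)cc2)cc1` gives 4.3 ug/mL

Among these three, compound 2 carries the highest number and so is the weakest inhibitor: from compound 1 the change was a 2.8-fold higher number from compound 1 to compound 2 (0.45 log units; beyond the scatter), and from compound 2 to compound 3 the number moves by a 2.4-fold lower number from compound 2 to compound 3 (0.38 log units; beyond the scatter). Both steps lie beyond the scatter, so the ranking holds.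

Compound 4 `CCCCCCCCCCCCOc1ccc(C(=O)/C=C/c2c(/C=C/c3ccc(OC)cc3)cc(OC)cc2OC)cc1` is built from compound 2 by one change: hexyl in place of hydrogen on a saturated chain carbon, six bonds along the chain from an oxygen on an aromatic ring. The hexyloxy group of compound 2 is thereby extended by a further six carbons.

Among the compounds with values here, the only measured step that touches this chain is the one in which hexyloxy first replaced hydrogen, a 2.8-fold higher number from compound 1 to compound 2 (0.45 log units; beyond the scatter), a modest rise. The reverse-like step, trifluoromethyl in place of hexyloxy, a 2.4-fold lower number from compound 2 to compound 3 (0.38 log units; beyond the scatter), lowered the number again. Within the data shown here, no measured step lengthens a chain that is already present, so the effect of adding six more carbons is uncertain; a small further rise, or no change beyond the scatter, seems most likely.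

Compound 4 is therefore expected to give about 15 ug/mL, within 6 ug/mL to 40 ug/mL, an estimated step of a 1.4-fold higher number from compound 2 to compound 4 (0.16 log units; within the scatter).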

Compound 4, half-maximal inhibitory concentration: 12.7 ug/mL
For compound 4 the middle estimate is 1.2-fold (0.07 log units) above the measured one; measured number inside the range.
By their numbers in this assay, from the lowest: compounds 1 and 3 (each within the scatter of the next); then compounds 2 and 4 (each within the scatter of the next).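

In this assay, adding hexyl on a saturated chain carbon, six bonds along the chain from an oxygen on an aromatic ring, gives a 1.2-fold higher number from compound 2 to compound 4 (0.09 log units; within the scatter) and leaves the two compounds within the scatter of each other. The earlier compounds shown here showed only what happens when hexyloxy first replaces hydrogen on an aromatic carbon, a 2.8-fold higher number from compound 1 to compound 2 (0.45 log units; beyond the scatter) and so a step beyond the scatter. Here, for the first time, a chain already in place is lengthened, and at this position the added hexyl brings no change that this read-out can distinguish. No measurement among those shown offers an explanation for this result.

The compounds shown leave open whether a still longer chain would also stay within the scatter of compound 2, or whether a shorter chain such as butyl would fall between compound 1 and compound 2. They also leave open whether a polar end group on the chain, such as an amine or a carboxylic acid, would shift the number where added carbons did not.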